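A few compounds are considered here, and "the series" means these few. Any claim that something is new, unique, unknown or untested is made for them only; others in the source may bear on it.

Measured compounds:
- compound 1 `N#CC1=C(N)Oc2c(c3nc4ccccc4nc3c3ccccc23)C12C(=O)N(Cc1cnnn1-c1ccc(Br)cc1)c1ccccc12`: in a functional assay on HCT-116 cells (Homo sapiens) for antiproliferative activity, read by MTT assay, with a stated time of 48 h (a lower number here means a stronger inhibitor, a higher number a weaker inhibitor), compound 1 gives > 50000 nM, a limit of the assay.
- compound 2 `Cc1cc(C)cc(-n2nncc2CN2C(=O)C3(C(C#N)=C(N)Oc4c3c3nc5ccccc5nc3c3ccccc43)c3ccccc32)c1`: in this assay compound 2 gives > 50000 nM, also a limit.
- compound 3 `N#CC1=C(N)Oc2c(N)cc3nc4ccccc4nc3c2C12C(=O)N(Cc1cnnn1-c1ccccc1Br)c1ccccc12`: in this assay compound 3 gives 12400 nM.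

Among the measured compounds shown here, compound 3 therefore holds the only number; the two other values are limits (the limit of > 50000 nM in this assay, at which 2 of the 3 values shown sit), so no ordering between compound 3 and the other two can be read from them beyond the fact that compound 3 alone returned a number. For the measured compounds named here, the only measured step, a step that the two limits leave unreadable from compound 1 to compound 2, concerns the same kind of position, 3,5-dimethylphenyl in place of 4-bromophenyl on an aromatic nitrogen, but its size is not readable.

Compound 4 `N#CC1=C(N)Oc2c(N)cc3nc4ccccc4nc3c2C12C(=O)N(Cc1cnnn1-c1ccc([N+](=O)[O-])cc1[N+](=O)[O-])c1ccccc12` differs from compound 3 by 2,4-dinitrophenyl in place of 2-bromophenyl on an aromatic nitrogen. Going by the values given here, no measured step shows how a change of the aryl group on this aromatic nitrogen moves the number, so the expectation rests on compound 3 alone. In this assay the expected step of a 1.2-fold higher number from compound 3 to compound 4 (0.08 log units; within the scatter) is none beyond the scatter, with some chance that the value again comes back as a limit. Compound 4 is estimated at 15000 nM, with a range from 4000 nM to 50000 nM.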

Compound 4, half-maximal inhibitory concentration: 23900 nM
For compound 4 the middle estimate is 1.6-fold (0.20 log units) below the measured one; the range from low to high includes it.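

In this assay, replacing 2-bromophenyl with 2,4-dinitrophenyl on the aromatic nitrogen gives a 1.9-fold higher number from compound 3 to compound 4 (0.28 log units; within the scatter). Among the compounds shown here, this is the first readable step at this position, and it shows no change beyond the scatter even though the entering group is larger and carries nitro groups where the leaving group carries a bromine. The earlier step at this position stays unreadable, and compound 4 returns a number rather than a limit, which adds a second measured point to a series otherwise marked by: the limit of > 50000 nM in this assay, at which 2 of the 4 values shown sit.

Two aryl groups on one core cannot show whether any group here moves the number beyond the scatter. A single nitro group, an amine or a carboxylic acid on this phenyl ring, or a plain methyl group in place of the aryl group, would test how far this tolerance extends.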